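A Double Bond Redrawn: From Compound 3 to Compound 4

The source may report more compounds than this note shows. Statements on the series, on what has been measured and on what is new or still open speak of the compounds shown alone.

Of the compounds shown here, three have been tested for their ability to kill cells in a functional assay on DLD-1 cells (Homo sapiens) for cytotoxicity, read by resazurin assay; on this read-out lower numbers stand for stronger inhibition and higher numbers for weaker inhibition. Compound 1 `CC1(C)[C@H](Br)[C@H](O)C[C@@]2(CO2)[C@@]12CCC(=O)[C@@H]1O[C@@H]12` gives >= 10000 nM, which is a limit of the assay and not a number. Compound 2 `CO[C@@]1(C)CC[C@]2(C[C@H]1Br)C(C)=C[C@H](O)CC2(C)C` gives >= 10000 nM, again a limit. Compound 3 `CC1=CC(=O)CC(C)(C)[C@@]12C=C/C(=C/Br)CC2` gives >= 10000 nM, and this too is a limit. The whole set therefore comes down to a single line: the limit of >= 10000 nM in this assay, at which 3 of the 3 values shown sit.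

The next compound to be measured is compound 4 `CC1=CC(=O)CC(C)(C)[C@@]12C=C/C(=C\Br)CC2`, a close relative of compound 3. Nothing leaves and nothing enters in this step, and the change is one of configuration alone: the two compounds have the same atoms and bonds and differ only in configuration as drawn: 1 of 2 stereo elements differ; a double bond is drawn E in compound 3 and Z in compound 4. Going by the values given here, no measured pair shows what such a change does in this assay, so there is no direct precedent to draw on. The expectation rests on compound 3 and its >= 10000 nM, a limit, and no shift beyond the scatter is expected. The estimated step is a number no higher from compound 3 to compound 4 (the limit leaves the size open), and it is expected to be small. For compound 4 the estimate is 10000 nM, with an expected range from 4000 nM to 20000 nM.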

Compound 4, half-maximal inhibitory concentration: >= 10000 nM
Compound 4 was reported as a limit; the forecaster's own chance of this, stated with the estimate: 80%; the middle value sits exactly at the limit.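

No step can be read from compound 3 to compound 4, because both results are limits and not numbers: the limit of >= 10000 nM in this assay, at which 4 of the 4 values shown sit.

The compounds shown leave open whether drawing the double bond E or Z makes any difference in this assay, and what kind of change would bring a value away from this limit.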